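This account rests on a few compounds, and the source may have more. Where it says the series, first, only, none or still open, it means among the compounds named here.

Measured so far in a functional assay on U-251 cells (Homo sapiens) for cytotoxicity, read by sulforhodamine B assay, with a stated time of 48 h; on this read-out higher numbers stand for weaker inhibition of growth and lower numbers for stronger inhibition of growth:

compound 1, `ClCc1ccc(Cn2cnc3c(Cl)ncnc32)cc1`, gives 1250 nM
compound 2, `ClCc1ccccc1Cn1cnc2ncnc(Cl)c21`, gives 1900 nM
compound 3, `ClCc1ccc(Cn2cnc3c(Cl)nc(Cl)nc32)cc1`, gives 2040 nM

Compound 3 differs from compound 1 by chloro in place of hydrogen on an aromatic carbon. This step gave a 1.6-fold higher number from compound 1 to compound 3 (0.21 log units; within the scatter), so the added chloro group left the read-out essentially unchanged within this pair.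

Compound 2 is built from the same atoms as compound 1, joined differently; the difference between the two cores is not broken down here. On this read-out compound 2 stands between compound 1 and compound 3, and all three values lie within the scatter of one another, so no order among the three is claimed.

Compound 4, `ClCc1ccccc1Cn1cnc2nc(Cl)nc(Cl)c21`, has not been measured. It differs from compound 2 by chloro in place of hydrogen on an aromatic carbon. The surroundings of the changed carbon are described in the same terms as for the change from compound 1 to compound 3, so this is taken to be the same change, now made on the core of compound 2 rather than the core of compound 1.

In this assay, for the measured compounds named here, the step from compound 2 to compound 4 is expected to be a 1.3-fold higher number from compound 2 to compound 4 (0.12 log units; within the scatter), because a 1.6-fold higher number from compound 1 to compound 3 (0.21 log units; within the scatter) is the only precedent for this change and lay within the scatter. Going by the values given here, only one precedent exists, so the range is kept wide.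

For compound 4 in this assay the estimated value is 2500 nM, expected to fall between 1200 nM and 5500 nM.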

Compound 4, concentration for 50% growth inhibition: 330 nM
Compound 4: the middle estimate sits 7.6-fold (0.88 log units) above what was measured, outside the stated range (below it).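

Chloro in place of hydrogen on an aromatic carbon, between two ring nitrogen atoms, does not carry over as a step of one size between the two cores in this assay: the same change on two cores in this assay, a 1.6-fold higher number (0.21 log units; within the scatter) from compound 1 to compound 3 and a 5.8-fold lower number (0.76 log units; beyond the scatter) from compound 2 to compound 4, 9.4-fold (0.97 log units) apart, beyond the scatter of two such steps

On the core of compound 2 the change gives a 5.8-fold lower number from compound 2 to compound 4 (0.76 log units; beyond the scatter) and stands as a real step, whereas on the core of compound 1 it gives a 1.6-fold higher number from compound 1 to compound 3 (0.21 log units; within the scatter) and cannot be told apart from no change. This shows that a step read on one core of this series is not a safe guide to the other core, but it rests on one pair per core, and it does not show which feature of the differently joined cores sets the two steps apart, nor whether the gain on the core of compound 2 would appear on any other core or on other cells.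

From the compounds shown here alone, whether an amine or a methoxy group on that same carbon would give a step like that of the chloro group on the core of compound 2 stays open. Also open, going by these compounds, is whether a hydrogen or a hydroxy group in place of the other chloro group on the ring would keep the growth inhibition seen for compound 4.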